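Removing the para chloro from compound 3: an expected step

A few compounds are considered here, and "the series" means these few. Any claim that something is new, unique, unknown or untested is made for them only; others in the source may bear on it.

Going by the values given here, compound 3 `O=C1c2ccccc2N(Cc2ccccc2)S(=O)(=O)N1Cc1ccc(Cl)cc1` is one of three compounds measured in a functional assay on HEL cells (Homo sapiens) for inhibition; a lower number here means that less compound is tolerated, a higher number that more compound is tolerated. In that assay compound 3 gives 121000 nM. Compound 1 `O=C1c2ccccc2N(Cc2ccccc2Cl)S(=O)(=O)N1Cc1ccccc1` gives 88000 nM in this assay, a value lying within the usual scatter of that of compound 3, so the two cannot be ranked. Compound 2 `O=C1c2ccccc2N(Cc2cccc(Cl)c2)S(=O)(=O)N1Cc1ccccc1` reaches only (the limit of > 200000 nM in this assay, at which 1 of the 3 values shown sits), reported as > 200000 nM in this assay, which is a limit and not a number. Among the compounds with values here, the one step measured in one place, an at least 2.2-fold higher number from compound 1 to compound 2 (0.35 log units; beyond the scatter), concerns the position of a chloro group rather than its removal.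

Compound 4 `O=C1c2ccccc2N(Cc2ccccc2)S(=O)(=O)N1Cc1ccccc1` differs from compound 3 by hydrogen in place of chloro on an aromatic carbon. No measured step bears directly on losing a chloro group; the only step shown moved one. Compound 4 is therefore expected to give 130000 nM in this assay, between 60000 nM and 250000 nM, a step of a 1.1-fold higher number from compound 3 to compound 4 (0.03 log units; within the scatter) that is estimated to stay within the scatter.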

Compound 4, half-maximal cytotoxic concentration: > 200000 nM
Compound 4 ended at the assay's limit; the forecaster's own chance of this, stated with the estimate: 30%; middle value at least 1.5-fold (0.18 log units) from the limit.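

In this assay, hydrogen in place of chloro at this position gives an at least 1.6-fold higher number from compound 3 to compound 4 (0.21 log units; that floor lies within the scatter), so the change does not lower the number, though its floor cannot show a real rise. Going by these compounds alone, the same replacement on the other benzyl group of the shared core gives an at least 2.2-fold higher number from compound 1 to compound 4 (0.35 log units; beyond the scatter), which is the first readable sign that a chloro group can carry a cost, and it comes from that benzyl group rather than from this position. The remaining step cannot be read, with both of its ends at a limit: the limit of > 200000 nM in this assay, at which 2 of the 4 values shown sit.

Going by these compounds, how far the unsubstituted compound 4 lies past its limit stays unknown, so the full size of both readable steps is open. On these data alone, whether a methoxy group, an amine or a carboxylic acid in place of the chloro group would bring the number down to a measurable value also remains open.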